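A few compounds are considered here, and "the series" means these few. Any claim that something is new, unique, unknown or untested is made for them only; others in the source may bear on it.

Measured compounds:
compound 1, `COc1ccc(C2CCc3nc[nH]c3C2)cc1`, in an in vitro ADME assay on microsomes from liver (Homo sapiens) for metabolic stability; on this read-out higher numbers stand for fast clearance and lower numbers for slow clearance: 16 mL.min-1.g-1
compound 2, `Fc1ccccc1C1Cc2nccn2C1`, in this assay: "not determined" (no result reported)

Among the measured compounds shown here, compound 1 is the only compound here that carries a number: in this assay compound 1 gives 16 mL.min-1.g-1. Compound 2 is built on a different core, and for compound 2 this assay reports "not determined" (no result reported), so compound 2 stands on no single number at all. Compound 3, `N#Cc1ccccc1C1Cc2nccn2C1`, differs from compound 2 in one place, cyano in place of fluoro on an aromatic carbon: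

cyano in place of fluoro on an aromatic carbon

For the measured compounds named here, no result exists for compound 2 and no step is known within this core, so no size and no direction can be read for the change from compound 2 to compound 3 in this assay, and nothing measured says whether it lies beyond the scatter. The expectation for compound 3 in this assay is accordingly loosely held, estimated at 6 mL.min-1.g-1 with a range from 1.5 mL.min-1.g-1 to 25 mL.min-1.g-1.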

Compound 3, intrinsic clearance in microsomes: < 7 mL.min-1.g-1
Compound 3: only a limit was reported (the forecaster's own chance of this, stated with the estimate: 20%); the middle value lies beyond the limit too.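

In this assay compound 3 gives < 7 mL.min-1.g-1, a limit of the assay and not a number. Among the compounds shown here, no step from compound 2 to compound 3 can be read, as compound 2 carries no number. The compounds shown leave open whether cyano in place of fluoro on an aromatic carbon shifts this read-out at all, and in which direction.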